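Compound 2 to Compound 3: Expected Tolerance on Huh-7 Cells

A few compounds are considered here, and "the series" means these few. Any claim that something is new, unique, unknown or untested is made for them only; others in the source may bear on it.

Compound 1 `CC(C)(C)c1ccc(C(=O)NC(=S)N2CCc3c(OCCCCCOc4ccc(Cl)cc4)cccc32)cc1`: in an ADME assay on Huh-7 cells (Homo sapiens) for cytotoxicity (a lower number here means that less compound is tolerated, a higher number that more compound is tolerated), compound 1 gives > 50000 nM, a limit of the assay and not a number.
Compound 2 `CN(C)c1ccc(C(=O)NC(=S)N2CCc3c(OCCCCCOc4ccc(Cl)cc4)cccc32)cc1`: in this assay compound 2 gives > 50000 nM, again a limit of the assay rather than a number.

Compound 2 thus stands at the limit of this assay, the point where both values shown sit (the limit of > 50000 nM in this assay, at which 2 of the 2 values shown sit). Going by the values given here, the only measured step, a step that the two limits leave unreadable from compound 1 to compound 2, runs between two limits, so its size cannot be read; it shows only that both compounds were tolerated up to the limit.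

Compound 3 `O=C(NC(=S)N1CCc2c(OCCCCCOc3ccc(Cl)cc3)cccc21)c1cccnc1` differs from compound 2 by pyridin-3-yl in place of 4-(dimethylamino)phenyl on a carbonyl carbon. Among the compounds with values here, no measured step bears on this change, since the single step available concerns a different position and is itself unreadable. With compound 2 at the limit > 50000 nM and nothing in the data pointing to a change beyond the scatter, the expectation for compound 3 is a step of a number no higher from compound 2 to compound 3 (the limit leaves the size open), which is to say no movement that could be read. Compound 3 is therefore expected to give 50000 nM in this assay, within 20000 nM to 100000 nM, most likely reported again as a limit.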

Compound 3, half-maximal cytotoxic concentration: 11100 nM
For compound 3 the middle estimate is 4.5-fold (0.65 log units) above the measured one; the whole stated range lies above it.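

In this assay the position on the carbonyl carbon proves able to move the read-out: pyridin-3-yl in place of 4-(dimethylamino)phenyl gives an at least 4.5-fold lower number from compound 2 to compound 3 (0.65 log units; beyond the scatter), and pyridin-3-yl in place of 4-(tert-butyl)phenyl gives an at least 4.5-fold lower number from compound 1 to compound 3 (0.65 log units; beyond the scatter). Going by these compounds alone, compound 3 is the only compound here with a number rather than a limit, so the shared core does not by itself keep a compound at the limit; what sits on the carbonyl carbon also counts. The two larger groups, 4-(dimethylamino)phenyl and 4-(tert-butyl)phenyl, stand together only in that neither brings the value down to a readable number: the limit of > 50000 nM in this assay, at which 2 of the 3 values shown sit.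

The compounds shown leave open whether the lower number goes with the ring nitrogen of pyridin-3-yl or with the loss of the group carried on the ring, a question that an unsubstituted phenyl on the same carbonyl carbon would address. They also leave open how far compound 1 and compound 2 really lie from compound 3, and the step between compound 1 and compound 2 cannot be read.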